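The source may report more compounds than this note shows. Statements on the series, on what has been measured and on what is new or still open speak of the compounds shown alone.

Compound 1 `Cc1cc(Nc2cc(Cl)c(Oc3ccccc3)c(Cl)c2)nc(N)n1`: > 180000 nM
Compound 2 `Cc1cc(Nc2cc(Cl)c(O)c(Cl)c2)nc(N)n1`: > 180000 nM

In an assay on cells for inhibition of S-adenosylmethionine decarboxylase proenzyme (Homo sapiens), read by mass spectrometry, at pH 7.2 (a lower number here means a stronger inhibitor, a higher number a weaker inhibitor), compound 1 gives > 180000 nM, which is a limit of the assay and not a number. In this assay compound 2 gives > 180000 nM, likewise a limit and not a number. The step from compound 1 to compound 2, a step that the two limits leave unreadable from compound 1 to compound 2, therefore has no readable size. For the measured compounds named here, the only evidence bearing on it is the limit of > 180000 nM in this assay, at which 2 of the 2 values shown sit. Compound 3 `Cc1cc(Nc2cc(Cl)c(OC(F)F)c(Cl)c2)nc(N)n1` differs from compound 2 by difluoromethyl in place of hydrogen on an oxygen on an aromatic ring. Going by the values given here, the one measured step that touches the same oxygen on the aromatic ring is the one from compound 1 to compound 2, and it yields no size, so no direction beyond the scatter can be expected in this assay for this change. Compound 3 is therefore expected to give 200000 nM, between 50000 nM and 1000000 nM, most probably again as a limit. The step so estimated, a step that the limit leaves unreadable from compound 2 to compound 3, is expected to stay within the scatter.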

Compound 3, half-maximal inhibitory concentration: > 63000 nM
Compound 3: no number, only a limit; the forecaster's own chance of this, stated with the estimate: 85%; the middle value is on the limit's open side.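

In this assay compound 3 gives > 63000 nM, which is a limit of the assay and not a number. For the compounds shown here, compound 1 and compound 2 also stand only at limits, so no step among compound 1, compound 2 and compound 3 can be read. The compounds shown leave open whether any group on this oxygen changes the inhibition at all.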